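Fluoro added to the phenyl ring of compound 3

The compounds below may be only part of what the source reports. "The series", "measured", "known", "first", "only" and "open" are said of these compounds alone.

Measured in a functional assay on ECa-109 cells (Homo sapiens) for antiproliferative activity, read by MTT assay, with a stated time of 72 h (on this read-out higher numbers stand for weaker inhibition and lower numbers for stronger inhibition), with each value a limit:
- compound 1 `CCCSc1nc(N/N=C/c2ccc(C)cc2)c2nnn(Cc3ccccc3)c2n1` with > 64000 nM as its limit
- compound 2 `CCCSc1nc(N/N=C/c2cccnc2)c2nnn(Cc3ccccc3)c2n1` with > 64000 nM as its limit
- compound 3 `CCCSc1nc(N/N=C/c2ccccc2)c2nnn(Cc3ccccc3)c2n1` with > 64000 nM as its limit

Compound 3 has no number on this read-out, only a limit. The whole set shares the limit of > 64000 nM in this assay, at which 3 of the 3 values shown sit, and so gives no ranking. Compound 4 `CCCSc1nc(N/N=C/c2ccccc2F)c2nnn(Cc3ccccc3)c2n1` has fluoro in place of hydrogen on an aromatic carbon so that phenyl becomes 2-fluorophenyl. The closest measured change, also on an aromatic carbon, is a step that the two limits leave unreadable from compound 1 to compound 3 and it gives no size to carry over. The aryl exchanges are no more informative, being a step that the two limits leave unreadable from compound 1 to compound 2 and a step that the two limits leave unreadable from compound 2 to compound 3 in turn. No shift beyond the scatter is therefore expected in this assay and no direction can be assigned, so a further limit is the likeliest result. The expected change is an at least 1.0-fold lower number from compound 3 to compound 4 (0.02 log units; that floor lies within the scatter) as an estimate only. Compound 4 is estimated at 60000 nM with an expected range from 20000 nM to 100000 nM on this evidence.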

Compound 4, half-maximal inhibitory concentration: > 64000 nM
Compound 4 was reported as a limit; the forecaster's own chance of this, stated with the estimate: 70%; middle value at least 1.0-fold (0.02 log units) away from the limit.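

In this assay compound 4 gives > 64000 nM, which is a limit. Going by these compounds alone, no step from compound 1, compound 2 or compound 3 to compound 4 can be read, as all four share one limit: the limit of > 64000 nM in this assay, at which 4 of the 4 values shown sit. Going by these compounds, whether any aryl group on the shared core gives a measurable value in this assay remains open.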